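A few compounds are considered here, and "the series" means these few. Any claim that something is new, unique, unknown or untested is made for them only; others in the source may bear on it.

Measured so far in an ADME assay on the whole organism (Mus musculus, strain CD1) for pharmacokinetics, read by LC-MS, with a stated time of 24 h, at a dose of 1 mg/kg by the intravenous route; a lower number here means that more of the compound stays in the plasma, a higher number that more of the compound sits outside the plasma:

Compound 1, `O=C(O)Cn1nc(Cc2nc3cc(Cl)c(OCC(F)F)cc3[nH]2)c2ccccc2c1=O`: 33 L/kg
Compound 2, `CC(C(=O)O)c1nn(Cc2cn3cc(OCC4CC4)c(C(F)(F)F)cc3n2)c2ccccc2c1=O`: 94 L/kg
Compound 3, `O=C(O)Cn1nc(Cc2cn3cc(OCC4CC4)c(Cl)cc3n2)c2ccccc2c1=O`: 21 L/kg

Compound 1 gives the second highest of the three numbers in this assay. Its nearest neighbour is compound 3, whose value of 21 L/kg lies within the scatter of repeated measurements, so nothing separates the two. Among the measured compounds shown here, compound 2, at 94 L/kg, stands beyond the scatter from compound 1; no single-point comparison links these two structures, so the pair shows only that the numbers differ. For the measured compounds named here, no step between two measured compounds that differ in one place is available.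

The step under consideration leads from compound 1 to compound 4, `O=C(O)Cn1nc(Cc2nc3cc(Cl)c(OCC4CC4)cc3[nH]2)c2ccccc2c1=O`, not yet measured. The change is cyclopropyl in place of difluoromethyl on a saturated chain carbon bound to an oxygen on an aromatic ring. Read one bond further out, it is 2,2-difluoroethoxy to cyclopropylmethoxy on the shared core of compound 1.

Going by the values given here, with no matched step in hand, the expectation for this assay is a small change, if any, with compound 4 somewhat on the higher side of compound 1 but not clearly beyond the scatter. Compound 4 is accordingly estimated at 40 L/kg, with a range from 18 L/kg to 90 L/kg, the expected step being a 1.2-fold higher number from compound 1 to compound 4 (0.08 log units; within the scatter).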

Compound 4, volume of distribution at steady state: 83 L/kg
Compound 4: the middle estimate sits 2.1-fold (0.32 log units) below what was measured, and the stated range covers the measured number.
By their numbers in this assay, from the lowest: compounds 3 and 1 (each within the scatter of the next); then compounds 4 and 2 (each within the scatter of the next).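

In this assay, among the compounds shown here, cyclopropyl in place of difluoromethyl on a saturated chain carbon bound to an oxygen on an aromatic ring gives a 2.5-fold higher number from compound 1 to compound 4 (0.40 log units; beyond the scatter) and provides the first comparison between compounds that differ in one place. The step shows that this position is not silent in this read-out: on the shared core of compound 1, exchanging 2,2-difluoroethoxy for cyclopropylmethoxy moves the number beyond the scatter of repeated measurements. The leaving and entering groups each have 3 heavy atoms, with no hydrogen-bond donors or acceptors and no net charge. Nothing available bears on the reason for the shift.

On these data alone, this remains a single pair on a single core, so whether the change gives a step of similar size on the cores of compound 2 or compound 3 stays open. Also open, as far as these compounds go, is how the number responds at this place to a simple methoxy group, a longer chain such as n-butyl, or a chain ending in an amine.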